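Shrinking the Substituent on the Amine Nitrogen

The compounds below may be only part of what the source reports. "The series", "measured", "known", "first", "only" and "open" are said of these compounds alone.

Compound 1 `[O-][n+]1nc(NC2CCCCC2)[n+]([O-])c2ccccc21` gives the lowest of the two numbers shown in a functional assay on MOLT-4 cells (Homo sapiens) for cytotoxicity, read by MTT assay, with a stated time of 48 h (on this read-out higher numbers stand for weaker inhibition and lower numbers for stronger inhibition), namely 1300 nM. Compound 2 `C=CCNc1n[n+]([O-])c2ccccc2[n+]1[O-]` gives 3000 nM. For compound 3 `CCN(CC)c1n[n+]([O-])c2ccccc2[n+]1[O-]` this assay reports only a limit, > 17600 nM. The change ethyl in place of cyclohexyl on a nitrogen on an aromatic ring yields compound 4 `CCNc1n[n+]([O-])c2ccccc2[n+]1[O-]`. The step that bears most on it is a 2.3-fold higher number from compound 1 to compound 2 (0.36 log units; beyond the scatter), where a smaller group likewise replaced cyclohexyl on that nitrogen. The step of an at least 5.8-fold higher number from compound 2 to compound 3 (0.76 log units; beyond the scatter) involves losing the hydrogen on that nitrogen, which compound 4 keeps, so it matters less here. A modest weakening is therefore expected: a 2.3-fold higher number from compound 1 to compound 4 (0.36 log units; beyond the scatter). Compound 4 is estimated at 3000 nM, with a range from 1200 nM to 8000 nM.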

Compound 4, half-maximal inhibitory concentration: 3300 nM
Compound 4: middle estimate off by 1.1-fold (0.04 log units), on the low side; the range from low to high includes it.
By their numbers in this assay, from the lowest: compound 1; then compounds 2 and 4 (each within the scatter of the next). At a limit, above all of these: compound 3.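

Ethyl and allyl on this nitrogen cannot be told apart, with a 1.1-fold higher number from compound 2 to compound 4 (0.04 log units; within the scatter). Cyclohexyl stays ahead of ethyl too, with a 2.5-fold higher number from compound 1 to compound 4 (0.40 log units; beyond the scatter), so the two smaller groups shown, saturated or not, fall short of it by similar margins. Hydrogen in place of ethyl on the same nitrogen gives an at least 5.3-fold lower number from compound 3 to compound 4 (0.72 log units; beyond the scatter), and this step starts from a limit, not a number: the limit of > 17600 nM in this assay, at which 1 of the 4 values shown sits.

Still open, going by these compounds, is whether a smaller ring such as cyclopentyl, or a longer chain ending in a hydroxyl or an amine, would come closer to cyclohexyl or stay with ethyl and allyl.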